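This account rests on a few compounds, and the source may have more. Where it says the series, first, only, none or still open, it means among the compounds named here.

Three compounds share one core. For the measured compounds named here, compound 1 `Cc1ncccc1-c1cnc(NCc2c(F)cc(C3CC3)c3c2CCO3)n2cnnc12` has no result in an ADME assay on cells (Hepatocyte, Rattus norvegicus) for metabolic stability (on this read-out higher numbers stand for fast clearance and lower numbers for slow clearance), where its entry reads "not determined" (no result reported); compound 2 `Cc1ncccc1-c1cnc(NCc2c(F)cc(F)c3c2CCO3)n2cnnc12` is the only compound with a number there, and in this assay compound 2 gives 9 uL/min, so it stands alone as the sole reference point. Compound 3 `Cc1ncccc1-c1cnc(NCc2c(F)cc(N)c3c2CCO3)n2cnnc12` differs from compound 2 in a single place: amino in place of fluoro on an aromatic carbon. Going by the values given here, no step between measured compounds is available to guide the size of this change. The step from compound 2 to compound 3 is expected to stay within the usual scatter, about no change at the digits printed from compound 2 to compound 3 (within the scatter). Compound 3 is therefore estimated at 9 uL/min, with a range from 4.5 uL/min to 18 uL/min.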

Compound 3, intrinsic clearance in a liver preparation (reported as CLH), per the amount of preparation that the assay uses in the Hepatocyte assay: 7 uL/min
Compound 3: middle estimate off by 1.3-fold (0.11 log units), on the high side; the measured number falls inside the stated range.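

In the Hepatocyte assay amino in place of fluoro on this aromatic carbon gives a 1.3-fold lower number from compound 2 to compound 3 (0.11 log units; within the scatter), so the swap leaves no clear mark on clearance. In a physicochemical assay for solubility, in phosphate buffer, with a stated time of 24 h, at pH 7.4 (on this read-out lower numbers stand for lower solubility and higher numbers for higher solubility), compound 2 gives 4000 nM and compound 3 gives 69000 nM. The amino group at this position therefore brings a large gain in solubility, something the earlier compounds could not show: the measured solubility of compound 2, 4000 nM, and of compound 3, 69000 nM, a 17-fold higher number (1.24 log units; beyond the scatter)

Still open, from the compounds shown here alone, is whether a hydroxyl or a dimethylamino group on this same aromatic carbon would give a similar gain with clearance held as steady.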